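This account rests on a few compounds, and the source may have more. Where it says the series, first, only, none or still open, it means among the compounds named here.

Compound 1, `NC(=O)c1cccc(NS(=O)(=O)c2cccc(C(F)(F)F)c2)c1`, is a sulfonamide built on a trifluoromethyl-bearing aryl ring. In an assay on isolated protein for inhibition of Calpain-1 catalytic subunit (Sus scrofa), read by FRET (a lower number here means a stronger inhibitor, a higher number a weaker inhibitor), compound 1 gives "not active" (no number reported), so no single number marks where it stands, only the finding that it showed no measurable inhibition. A second compound of a different build, compound 2 with the structure `FC(F)(F)c1ccc(CSc2nnc3ccc(-c4ccccn4)nn23)cc1`, was measured in this assay and gives 20500 nM, a weak result that serves as the only numerical anchor in this set.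

Compound 3, `O=C1CCCN1c1cccc(NS(=O)(=O)c2cccc(C(F)(F)F)c2)c1`, keeps the shared core of compound 1 and differs from it in one place: 2-oxopyrrolidin-1-yl in place of carbamoyl on an aromatic carbon. Going by the values given here, since compound 1 carries no number in this assay, no step between the two can be sized, and nothing in the data ties this change to a gain or a loss. With compound 1 showing no activity and the one numbered result, that of compound 2, lying far in the weak range, compound 3 is expected to remain a weak inhibitor at best. Compound 3 is therefore estimated at 40000 nM, within a range of 5000 nM to 300000 nM, and a report of no measurable activity is considered the more likely outcome.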

Compound 3, half-maximal inhibitory concentration: "not active" (no number reported)
No number was reported for compound 3; no gap can be computed for the estimate.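

No step can be read between compound 1 and compound 3: in this assay compound 1 gives "not active" (no number reported) and compound 3 likewise gives "not active" (no number reported) with no number to compare. No measured evidence bears on this result. The compounds shown leave open whether any group at this place on the shared core can bring measurable inhibition.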